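A few compounds are considered here, and "the series" means these few. Any claim that something is new, unique, unknown or untested is made for them only; others in the source may bear on it.

In an ADME assay on cells (Homo sapiens) for cytotoxicity, read by resazurin assay, with a stated time of 5 days (on this read-out higher numbers stand for lower toxicity in this test and lower numbers for higher toxicity in this test), compound 3 `COc1ccc(Nc2nc(CS(=O)(=O)c3cccc(Cl)c3)nc3ccsc23)cc1` gives 60000 nM. Compound 1 `COc1ccc(-c2nc(/C=C\c3cccc(Cl)c3)nc3ccsc23)cn1` gives 53000 nM, and these two numbers lie within the usual scatter of each other, so neither stands apart. Compound 2 `COc1ccc(-c2nc(C(C)(C)S(=O)(=O)c3cccc(Cl)c3)nc3ccsc23)cn1` gives > 50000 nM, which is a limit of the assay and not a number. All three measured compounds therefore show little toxicity in this test.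

The next compound to be tested is compound 4 `O=S(=O)(Cc1nc(-c2cccnc2)c2sccc2n1)c1cccc(Cl)c1`. It differs from compound 3 at a single place, on an aromatic carbon of the shared core: pyridin-3-yl in place of (4-methoxyphenyl)amino on an aromatic carbon. In words, pyridin-3-yl stands in place of (4-methoxyphenyl)amino.

Among the measured compounds shown here, no pair of measured compounds differs at only one place, so no direct precedent exists for this change. The expectation rests on the closely spaced numbers of compound 1 at 53000 nM and compound 3 at 60000 nM. The expected step of a 1.2-fold lower number from compound 3 to compound 4 (0.08 log units; within the scatter) is no larger than the usual scatter. For compound 4 the estimated value is 50000 nM, with an expected range from 20000 nM to 100000 nM.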

Compound 4, half-maximal cytotoxic concentration: > 50000 nM
Compound 4: no number, only a limit (the forecaster's own chance of this, stated with the estimate: 40%); the middle value sits exactly at the limit.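

Among the compounds shown here, compound 4 gives > 50000 nM, which is a limit of the assay and not a number, so no step from compound 3 to compound 4 can be read: the limit of > 50000 nM in this assay, at which 2 of the 4 values shown sit. The compounds shown leave open whether pyridin-3-yl in place of (4-methoxyphenyl)amino changes toxicity in this test at all.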